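The source may hold more compounds than are shown below. What is called first, only, known or untested is meant among the compounds shown, and "the series" means these compounds.

Measured compounds in an assay on IM-9 cells for displacement of a labelled ligand from Substance-P receptor (Homo sapiens), read by scintillation counting, with a stated time of 30 min; a lower number here means a stronger inhibitor, a higher number a weaker inhibitor:
compound 1 `Cc1cc(F)ccc1[C@H]1CN(C(N)=O)CC[C@@H]1C(=O)N(C)Cc1cc(C(F)(F)F)cc(C(F)(F)F)c1` gives 0.035 nM
compound 2 `CNC(=O)C(=O)N1CC[C@H](C(=O)N(C)Cc2cc(C(F)(F)F)cc(C(F)(F)F)c2)[C@@H](c2ccc(F)cc2C)C1` gives 0.11 nM

Within the data shown here, compound 2 holds the higher of the two numbers in this assay, that is the weaker binding of the pair; compound 1 sits a 3.1-fold higher number from compound 1 to compound 2 (0.50 log units; beyond the scatter) below it, with the only change being a methylcarbamoyl in place of amino on a carbonyl carbon.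

Compound 3 `Cc1cc(F)ccc1[C@H]1CN(C(=O)C(=O)NO)CC[C@@H]1C(=O)N(C)Cc1cc(C(F)(F)F)cc(C(F)(F)F)c1` is not yet measured. Against compound 2 the change is hydroxy in place of methyl on an amide-type nitrogen: a hydroxy in place of methyl on an amide-type nitrogen, so the methylcarbamoyl of compound 2 becomes hydroxycarbamoyl on the same carbonyl.

Of the measured steps, none alters this nitrogen. The step of a 3.1-fold higher number from compound 1 to compound 2 (0.50 log units; beyond the scatter) shows that the group on this carbonyl carbon is tolerated with only a modest loss when methylcarbamoyl replaces amino, which suggests the region accepts variation without large swings. Among the measured compounds shown here, the swap of methyl for hydroxy is a small change in size, and no measured pair speaks to a hydroxy here. The expectation for compound 3 is therefore a step of about a 1.4-fold higher number from compound 2 to compound 3 (0.13 log units; within the scatter) in this assay, within or near the scatter, with a slight lean toward a higher number. Compound 3 is thus estimated at 0.15 nM, in the range 0.05 nM to 0.5 nM.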

Compound 3, half-maximal inhibitory concentration: 0.046 nM
Estimate against measurement, compound 3: 3.3-fold (0.51 log units) above, and the stated range ends above it.
By their numbers in this assay, from the lowest: compounds 1 and 3 (each within the scatter of the next); then compound 2.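

In this assay, the group on this amide-type nitrogen matters in a way the earlier pair could not show: hydroxy in place of methyl gives a 2.4-fold lower number from compound 2 to compound 3 (0.38 log units; beyond the scatter), so the loss seen with methylcarbamoyl does not carry over to every (substituted carbamoyl)carbonyl group. Hydroxycarbamoyl in place of amino on the carbonyl carbon gives a 1.3-fold higher number from compound 1 to compound 3 (0.12 log units; within the scatter), which places compound 3 level with compound 1 within the scatter, so this larger group is accepted here without a measurable penalty when it ends in hydroxy rather than methyl. No measured property or other supporting data on hand accounts for the difference between hydroxy and methyl on this nitrogen.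

The compounds shown do not separate the role of the hydroxy hydrogen from that of the oxygen, a question that a methoxy on the same nitrogen would address, while a carboxylic acid or a dimethylamino group on the same carbonyl would test how far the position tolerates other ends. Whether the step from methyl to hydroxy holds with anything other than the shared core of these compounds also remains open.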